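From Arylsulfonyl to Dichlorobenzyl on the Ring Amine

The compounds below may be only part of what the source reports. "The series", "measured", "known", "first", "only" and "open" are said of these compounds alone.

Of the compounds shown here, three built on one shared core have been measured in a functional assay on K562 cells (Homo sapiens) for antiproliferative activity, read by MTT assay and trypan blue exclusion, with a stated time of 72 h; a lower number here means a stronger inhibitor, a higher number a weaker inhibitor. Compound 1 `COC(=O)c1ccc(C2SCC(=O)N2c2ccc(N3CCN(S(=O)(=O)c4ccc([N+](=O)[O-])cc4)CC3)cn2)c(OC)c1` gives 65200 nM. Compound 3 `COC(=O)c1ccc(C2SCC(=O)N2c2ccc(N3CCN(S(=O)(=O)c4c(C)cc(C)cc4C)CC3)cn2)c(OC)c1` gives 53500 nM; the step of a 1.2-fold lower number from compound 1 to compound 3 (0.09 log units; within the scatter) is within the scatter, so these two cannot be ordered. Compound 3 thus holds the lowest of the two numbers, with compound 1 within the scatter of it. Compound 2 `COC(=O)c1ccc(C2SCC(=O)N2c2ccc(N3CCN(Cc4cc(OC)c(OC)c(OC)c4)CC3)cn2)c(OC)c1` reaches only a limit of this assay and gives > 100000 nM.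

Compound 4 `COC(=O)c1ccc(C2SCC(=O)N2c2ccc(N3CCN(Cc4ccc(Cl)c(Cl)c4)CC3)cn2)c(OC)c1` differs from compound 3 by 3,4-dichlorobenzyl in place of (2,4,6-trimethylphenyl)sulfonyl on an amine nitrogen in a ring. For the measured compounds named here, no measured step covers this change: the single measured step exchanged one aryl for another on a sulfonyl sulfur and stayed within the scatter. Going by the values given here, the only other compound whose ring amine carries a benzyl rather than a sulfonyl group is compound 2, and its value is a limit, which is the one piece of evidence bearing on the direction; because the limit of > 100000 nM in this assay, at which 1 of the 3 values shown sits, sits where it does, a number at or near it cannot be ruled out for compound 4. A higher number, beyond the scatter, is therefore expected. Compound 4 is expected to give 95000 nM, between 40000 nM and 220000 nM, a step of a 1.8-fold higher number from compound 3 to compound 4 (0.25 log units; within the scatter) toward a weaker inhibitor, with a real chance that only a limit is recorded.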

Compound 4, half-maximal inhibitory concentration: > 100000 nM
Compound 4: only a limit was reported (the forecaster's own chance of this, stated with the estimate: 45%); at least 1.0-fold (0.02 log units) between middle value and limit.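

Compound 2 and compound 4, the two compounds with a benzyl-type group on the amine nitrogen in the ring, both stop at a limit in this assay, while the two arylsulfonyl compounds, compound 1 and compound 3, both give numbers, and no compound shown goes against this split: the limit of > 100000 nM in this assay, at which 2 of the 4 values shown sit. The change from sulfonyl to 3,4-dichlorobenzyl now has a lower bound on its size, an at least 1.8-fold higher number from compound 3 to compound 4 (0.27 log units; that floor lies within the scatter) and an at least 1.5-fold higher number from compound 1 to compound 4 (0.18 log units; that floor lies within the scatter), but both floors lie within the scatter, so neither step by itself establishes a real loss. The step between compound 2 and compound 4 cannot be read, as both values are limits, so exchanging 3,4,5-trimethoxyphenyl for 3,4-dichlorophenyl shows nothing here.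

On these data alone, what stays open is how far the benzyl compounds actually lie from the sulfonyl compounds, and whether the split would hold for an unsubstituted benzyl, an acetyl or a bare ring amine on that nitrogen. The compounds shown also leave open whether a carboxylic acid or an amide in place of the methyl ester would shift any of these values.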